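The source may hold more compounds than are shown below. What is called first, only, known or untested is meant among the compounds shown, and "the series" means these compounds.

In a functional assay on A549 cells (Homo sapiens) for cytotoxicity, read by MTT assay, with a stated time of 48 h (a higher number here means a weaker inhibitor, a lower number a stronger inhibitor), compound 3 (`Cc1cccc(/C=C/[C@](C)(O)CC[C@@H]2[C@@]3(C)CCCC(C)(C)[C@@H]3CC[C@@]2(C)O)c1C`) gives 3800 nM, level with compound 1 (`CC1(C)CCC[C@]2(C)[C@@H](CC[C@@](C)(O)/C=C/c3cccc([N+](=O)[O-])c3)[C@](C)(O)CC[C@@H]12`) at 3400 nM and well short of compound 2 (`COc1cccc(OC)c1/C=C/[C@](C)(O)CC[C@@H]1[C@@]2(C)CCCC(C)(C)[C@@H]2CC[C@@]1(C)O`) at 42000 nM. Compound 4 (`Cc1cccc(C)c1/C=C/[C@](C)(O)CC[C@@H]1[C@@]2(C)CCCC(C)(C)[C@@H]2CC[C@@]1(C)O`) differs from compound 3 by one exchange: 2,6-dimethylphenyl in place of 2,3-dimethylphenyl on a double-bonded chain carbon bound to a double-bonded chain carbon. Earlier exchanges at this place were silent in one case, a 1.1-fold higher number from compound 1 to compound 3 (0.05 log units; within the scatter), and large in another, a 12-fold higher number from compound 1 to compound 2 (1.09 log units; beyond the scatter). For the measured compounds named here, the nearest precedent is the 2,6-dimethoxyphenyl of compound 2, but it carries different groups, so only part of an 11-fold lower number from compound 2 to compound 3 (1.04 log units; beyond the scatter) is expected to return in reverse. The expected change is a moderate rise, a 2.4-fold higher number from compound 3 to compound 4 (0.37 log units; beyond the scatter). Compound 4 is therefore estimated at 9000 nM, with an expected range of 2800 nM to 32000 nM.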

Compound 4, half-maximal inhibitory concentration: 3340 nM
Compound 4: middle estimate off by 2.7-fold (0.43 log units), on the high side; low and high end bracket the measured number.
By their numbers in this assay, from the lowest: compounds 4, 1 and 3 (each within the scatter of the next); then compound 2.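

The exchange of 2,3-dimethylphenyl for 2,6-dimethylphenyl proved silent in this assay, with a 1.1-fold lower number from compound 3 to compound 4 (0.06 log units; within the scatter), so 2,6-dimethylphenyl does not bring the loss seen with compound 2. Replacing 2,6-dimethoxyphenyl with 2,6-dimethylphenyl gave a 13-fold lower number from compound 2 to compound 4 (1.10 log units; beyond the scatter), which ties that loss, among these compounds, to the methoxy groups. The 3-nitrophenyl group also stayed level with 2,6-dimethylphenyl, at a 1.0-fold lower number from compound 1 to compound 4 (0.01 log units; within the scatter). As far as these compounds go, whether a phenyl ring bearing an amine or a carboxylic acid at this place would stay level remains open. Nothing available explains the difference between the methoxy and methyl groups.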